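A few compounds are considered here, and "the series" means these few. Any claim that something is new, unique, unknown or untested is made for them only; others in the source may bear on it.

Measured compounds in this series:

- Compound 1 `CCCOc1c(C(=O)N(C)Cc2cc(C(F)(F)F)cc(C(F)(F)F)c2)c(=O)n(C)c2ccccc12` — an assay for inhibition of phosphatidylcholine:ceramide cholinephosphotransferase 2 (Mus musculus), read by mass spectrometry, with stated times of 60 min and 30 min; a higher number here means a weaker inhibitor, a lower number a stronger inhibitor: "not determined" (no result reported)
- Compound 2 `CN(Cc1cc(C(F)(F)F)cc(C(F)(F)F)c1)C(=O)c1c(OCCCC2CCN(C(=O)OC3(C)CC3)CC2)c2cccnc2n(C)c1=O` — this assay: 3 nM
- Compound 3 `CN(Cc1cc(C(F)(F)F)cc(C(F)(F)F)c1)C(=O)c1c(N2CCCC2)c2ccccc2n(C)c1=O` — this assay: 1100 nM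

Compound 3 stands at the highest of the two numbers reported in this assay; its nearest neighbour is compound 2, whose number is far lower, well beyond the scatter, and compound 1 contributes no number at all. Among the measured compounds shown here, no step between two measured compounds that differ in a single place is available, so the series offers no directly comparable single change.

Compound 4 `CN(Cc1cc(C(F)(F)F)cc(C(F)(F)F)c1)C(=O)c1c(OCCCC(F)(F)F)c2ccccc2n(C)c1=O` is the compound to be measured next. It differs from compound 3 in one place: 4,4,4-trifluorobutoxy in place of pyrrolidin-1-yl on an aromatic carbon. Compound 4 thus carries a chain in the position where compound 3 carries a ring, and in this respect its structure resembles that of compound 2 more than that of compound 3.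

A sizeable downward step from compound 3 to compound 4 is expected, an 18-fold lower number from compound 3 to compound 4 (1.26 log units; beyond the scatter), because compound 2 gives 3 nM. For compound 4 the estimate in this assay is 60 nM, within a range from 10 nM to 400 nM.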

Compound 4, half-maximal inhibitory concentration: 240 nM
Estimate against measurement, compound 4: 4.0-fold (0.60 log units) below; measured number inside the range.
By their numbers in this assay, from the lowest: compound 2; then compound 4; then compound 3.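

In this assay, among the compounds shown here, this is the first comparison that changes one place only: 4,4,4-trifluorobutoxy in place of pyrrolidin-1-yl, on the aromatic carbon opposite the ring nitrogen, gives a 4.6-fold lower number from compound 3 to compound 4 (0.66 log units; beyond the scatter). The step lies beyond the usual scatter, so the number responds to what this carbon carries, and an open chain with no ring is accepted here without any rise in the number. Nothing measured accounts for the size or direction of this step.

For the compounds shown here, the exchange alters the ring, the linking atom, the chain and the fluorine content all at once, and compound 1 gives no number in this assay, so no step to or from it can be read and the share of each alteration stays unknown. A plain butoxy chain at this carbon would test the terminal fluorines, and a piperidine ring or an open dialkylamine in place of pyrrolidin-1-yl would show whether a nitrogen-linked group can reach the level of compound 4.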